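Swapping the Sulfonyl Aryl Group and Its Effect on Factor X Inhibition Numbers

The source may hold more compounds than are shown below. What is called first, only, known or untested is meant among the compounds shown, and "the series" means these compounds.

Three compounds share a core in which a ring amide carries a sulfonamide, and each was tested in an assay on isolated protein for inhibition of coagulation factor X (Oryctolagus cuniculus), tested at 1 uM; on this read-out lower numbers stand for less inhibition and higher numbers for more inhibition at the one concentration tested (going by the name of the read-out). Compound 1 `O=C1[C@@H](NS(=O)(=O)c2cc3ccnc(Cl)c3s2)CCN1CCNc1ccncc1` gives 23%. Compound 2 `O=C1[C@@H](NS(=O)(=O)c2cc3ccnc(Cl)c3s2)CCN1Cc1cc2[nH]cccc-2n1` gives 45%, the highest of the three numbers, while compound 3 `O=C1[C@@H](NS(=O)(=O)c2cc3ccnc(Cl)c3s2)CCN1Cc1cc2c[nH]ccc-2n1` gives 25%. Every measured step between these three lies on the saturated chain carbon bound to the amide-type nitrogen in the ring: a number 22 percentage points higher from compound 1 to compound 2 (beyond the scatter), a number 2 percentage points higher from compound 1 to compound 3 (within the scatter), and a number 20 percentage points lower from compound 2 to compound 3 (beyond the scatter).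

Compound 4 `O=C1[C@@H](NS(=O)(=O)c2ccc(-c3ccon3)s2)CCN1Cc1cc2[nH]cccc-2n1` differs from compound 2 at a different place, on the sulfonyl sulfur: a group of 10 heavy atoms (7 carbon, 1 nitrogen, 1 oxygen, 1 sulfur; one five-membered aromatic ring with 1 hetero atom, one five-membered aromatic ring with 2 hetero atoms) in place of a group of 10 heavy atoms (7 carbon, 1 nitrogen, 1 sulfur, 1 chlorine; one five-membered aromatic ring with 1 hetero atom, one six-membered aromatic ring with 1 hetero atom), on a sulfonyl sulfur. Within the data shown here, none of the measured steps touches this sulfonyl position, so no measured step bears on the change, and the three numbers give no guide to its direction or size. Among the measured compounds shown here, what is known is only that compound 2 sits at the top of the measured range, which leaves room for a number either higher or lower.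

With nothing to lean on, the estimated step of a number 7 percentage points lower from compound 2 to compound 4 (within the scatter) is expected to be small, with a wide range. In this assay compound 4 is estimated at 38%, expected to fall between 8% and 70%.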

Compound 4, a percentage reported as inhibition, at one concentration (the size of the read-out at that concentration, not a potency): 31%
The estimate for compound 4 lay 7 percentage points above the measured number; measured number inside the range.
By their numbers in this assay, from the lowest: compounds 1, 3 and 4 (each within the scatter of the next); then compound 2.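

The sulfonyl sulfur turns out to be a second place that matters: in this assay, putting 5-(1,2-oxazol-3-yl)thiophen-2-yl on it gives a number 14 percentage points lower from compound 2 to compound 4 (beyond the scatter), so the number responds to more than the saturated chain carbon bound to the amide-type nitrogen in the ring. The group that leaves and the group that enters have the same count of heavy atoms, so this step changes what those atoms are rather than how many there are: chlorine and a six-membered aromatic ring go out, and oxygen and a five-membered aromatic ring with 2 hetero atoms come in. No measurement at hand says what lies behind the step.

As far as these compounds go, this is a single swap, made with one group on the amide-type nitrogen, so it remains open whether the same swap would shift the number in the same way with the group carried by compound 1 or compound 3. From the compounds shown here alone, it is also open how the number would respond on the sulfonyl sulfur to a plain phenyl, or to a thiophene carrying an amine or a carboxylic acid in place of the 1,2-oxazol-3-yl.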